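From 4-chlorophenyl to 3-methylphenyl on the carbonyl carbon

The source may hold more compounds than are shown below. What is called first, only, known or untested is meant among the compounds shown, and "the series" means these compounds.

Of the compounds shown here, two have been measured so far in a functional assay on a cell-free system (Platelet, plasma, Homo sapiens) for inhibition; a lower number here means a stronger inhibitor, a higher number a weaker inhibitor. Compound 1 (`Cc1ccc(N(CCN2CCC(OCC(=O)O)CC2)C(=O)c2ccc(Cl)cc2)cc1`) gives 690 nM and compound 2 (`O=C(O)COC1CCN(CCN(C(=O)c2ccc(Cl)cc2)c2ccc(Cl)cc2)CC1`) gives 1500 nM as the higher of the two numbers, which makes it the weaker inhibitor of the pair. For the measured compounds named here, the one measured step (a 2.2-fold higher number from compound 1 to compound 2 (0.34 log units; beyond the scatter)) is modest and puts chloro in place of methyl on an aromatic carbon. Compound 3 (`Cc1cccc(C(=O)N(CCN2CCC(OCC(=O)O)CC2)c2ccc(Cl)cc2)c1`) departs from compound 2 elsewhere, with 3-methylphenyl in place of 4-chlorophenyl on a carbonyl carbon. The group on that carbonyl carbon stayed the same in the measured step, so no measurement speaks to this change directly. Going by the values given here, the only guide is indirect: methyl rather than chloro went with the lower number in that step (a 2.2-fold higher number from compound 1 to compound 2 (0.34 log units; beyond the scatter)), at another place in the molecule. A small move toward a lower number in this assay is therefore expected, and the estimated step (a 1.5-fold lower number from compound 2 to compound 3 (0.18 log units; within the scatter)) stays within the scatter. For compound 3 the estimate is 1000 nM (expected range 350 nM to 3000 nM).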

Compound 3, half-maximal inhibitory concentration: 310 nM
Compound 3: the middle estimate sits 3.2-fold (0.51 log units) above what was measured; measured number below the stated range.
By their numbers in this assay, from the lowest: compound 3; then compound 1; then compound 2.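

The group on the carbonyl carbon, held fixed in the earlier pair, now proves to matter in this assay: 3-methylphenyl in place of 4-chlorophenyl gives a 4.8-fold lower number from compound 2 to compound 3 (0.68 log units; beyond the scatter), a step beyond the usual scatter. Read with a 2.2-fold higher number from compound 1 to compound 2 (0.34 log units; beyond the scatter), at an aromatic carbon elsewhere in the molecule, this gives two places where methyl and chloro have been exchanged, and in both pairs the compound carrying methyl has the lower number, although two pairs are a very small basis and say nothing about other groups. No measurement shown accounts for the size or direction of the new step.

The new step changes two things at once, the substituent and its place on the ring, so the compounds shown cannot tell whether the lower number follows the methyl itself or where it sits. An unsubstituted phenyl or a methoxyphenyl on the same carbonyl carbon would be needed to show how much of the step belongs to the methyl and whether that position accepts other groups.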